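Chloro in place of methyl: compound 3 from compound 2

This account rests on a few compounds, and the source may have more. Where it says the series, first, only, none or still open, it means among the compounds named here.

Within the data shown here, compound 2 `Cc1ccc(NS(C)(=O)=O)c2c1C(c1c[nH]cn1)CCC2` is the only member of this set with a number: in an assay on isolated protein for binding affinity to Alpha-1D adrenergic receptor (Rattus norvegicus), read by radioligand binding (a higher number here means a weaker inhibitor, a lower number a stronger inhibitor), compound 2 gives 2690 nM. Compound 1 `CS(=O)(=O)Nc1ccc(O)c2c1CCCC2c1c[nH]cn1` sits at a limit of this assay, < 10000 nM. The step from compound 1 to compound 2 a step that the limit leaves unreadable from compound 1 to compound 2 cannot be sized because of the limit of < 10000 nM in this assay, at which 1 of the 2 values shown sits. Compound 3 `CS(=O)(=O)Nc1ccc(Cl)c2c1CCCC2c1c[nH]cn1` differs from compound 2 by chloro in place of methyl on an aromatic carbon. No measured step bears on this change, the single step shown being unreadable. The expected step is therefore none beyond the scatter, a 1.1-fold lower number from compound 2 to compound 3 (0.03 log units; within the scatter). Compound 3 is estimated at 2500 nM, within a range from 800 nM to 8000 nM.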

Compound 3, inhibition constant: 2880 nM
Beside the measured number, compound 3's estimate is 1.2-fold (0.06 log units) below it; the range from low to high includes it.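

Para to the methanesulfonamido group, chloro in place of methyl gives a 1.1-fold higher number from compound 2 to compound 3 (0.03 log units; within the scatter) in this assay, the first readable step at this position. Methyl and chloro, each a single heavy atom, are therefore not told apart here. Compound 1 is a limit, < 10000 nM, and the steps from it to compound 2 and compound 3 cannot be read: the limit of < 10000 nM in this assay, at which 1 of the 3 values shown sits.

As far as these compounds go, how hydroxy compares with methyl or chloro at this position stays open. Also open, from the compounds shown here alone, is whether an amine, a methoxy group or a longer chain there would move the number beyond the scatter.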